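This account rests on a few compounds, and the source may have more. Where it says the series, first, only, none or still open, it means among the compounds named here.

Measured so far:
compound 1 `Nc1nc2cc(OC(F)(F)F)ccc2s1` — > 10 mg/kg in a functional assay on the whole organism with Rattus norvegicus as the target; a higher number here means that more compound is needed for the effect, a lower number that less compound is needed
compound 2 `COC(=O)Cn1c(=N)sc2cc(OC(F)(F)F)ccc21` — > 10 mg/kg

In this assay compound 1 reaches only a limit of the assay, > 10 mg/kg, and no number. Compound 2 likewise gives only a limit in this assay, > 10 mg/kg. Where compound 2 stands is therefore not a position on a scale: both values shown in this assay sit at the same limit, (the limit of > 10 mg/kg in this assay, at which 2 of the 2 values shown sit), so compound 2 cannot be ordered against compound 1, and no step between the two measured compounds can be counted.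

Compound 3 `CCCSCCn1c(=N)sc2cc(OC(F)(F)F)ccc21` is not yet measured in this assay. Compared with compound 2 the change is (propylsulfanyl)methyl in place of methoxycarbonyl on a saturated chain carbon bound to an aromatic nitrogen. Among the compounds with values here, with no measured step to lean on, the size of the step from compound 2 to compound 3 is expected to be small, a step that the limit leaves unreadable from compound 2 to compound 3, with no direction beyond the scatter to be read from two limits. Compound 3 is expected at 15 mg/kg, within a range from 3 mg/kg to 60 mg/kg, and most likely it will again be reported as a limit in this assay.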

Compound 3, dose for half-maximal effect: 2.4 mg/kg
Estimate against measurement, compound 3: 6.3-fold (0.80 log units) above; measured number outside the range, below it.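

Replacing methoxycarbonyl with (propylsulfanyl)methyl on a saturated chain carbon bound to an aromatic nitrogen gives, in this assay, an at least 4.1-fold lower number from compound 2 to compound 3 (0.61 log units; beyond the scatter). This position therefore tolerates a change that moves the read-out beyond the scatter, and compound 3 is the only compound shown with a number rather than a limit. The step can be given only as a minimum, because the value of compound 2 is a limit and not a number: the limit of > 10 mg/kg in this assay, at which 2 of the 3 values shown sit.

The single change removes the ester and brings in a sulfur-containing chain together, so the compounds shown do not separate the loss of the methoxycarbonyl group from the gain of the 2-(propylsulfanyl)ethyl chain. Also open, going by these compounds, is whether the sulfur itself or the chain as a whole goes with the lower number in this assay, a question that a 2-propoxyethyl chain with oxygen in place of sulfur, a purely carbon chain, or a longer thioether chain at the same place would address.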